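The source may report more compounds than this note shows. Statements on the series, on what has been measured and on what is new or still open speak of the compounds shown alone.

Compound 1, with the structure `COc1ccc(C2=[N+]3C(=Nc4c(-c5ccccc5)c5c(n4[B-]3(F)F)-c3ccc(OCC(=O)O)cc3CC5)C(c3ccccc3)=C2I)cc1`, carries a carboxymethyl group on its core. In a functional assay on HeLa cells (Homo sapiens) for cytotoxicity, read by CCK-8 assay, with a stated time of 16 h (a lower number here means a stronger inhibitor, a higher number a weaker inhibitor), compound 1 gives no number but only a limit of the assay, > 50000 nM. Compound 2, with the structure `COc1ccc(C2=[N+]3C(=Nc4c(-c5ccccc5)c5c(n4[B-]3(F)F)-c3ccc(OCC(=O)N[C@@H](CC(=O)O)C(=O)O)cc3CC5)C(c3ccccc3)=C2I)cc1`, carries the same core, but here the change (1,2-dicarboxyethyl)amino in place of hydroxy on a carbonyl carbon has been made. In this assay compound 2 likewise reaches only a limit, > 250000 nM. Because both ends of this pair are limits, the step that the two limits leave unreadable from compound 1 to compound 2 cannot be read as a size; all that is visible is that both compounds sit at or beyond the edge of what the assay can report, which is also what the two lines the limit of > 250000 nM in this assay, at which 1 of the 3 values shown sits, and the limit of > 50000 nM in this assay, at which 2 of the 3 values shown sit, record.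

Compound 3, with the structure `COc1ccc2c(c1)CCc1c(-c3ccccc3)c3n(c1-2)[B-](F)(F)[N+]1=C(c2ccc(OCC(=O)O)cc2)C(I)=C(c2ccccc2)C1=N3`, is built from the same atoms as compound 1 joined in a different way; the difference between the two cores is not broken down here. In this assay compound 3 again gives only a limit, > 50000 nM.

Compound 4, with the structure `COc1ccc2c(c1)CCc1c(-c3ccccc3)c3n(c1-2)[B-](F)(F)[N+]1=C(c2ccc(OCC(=O)N[C@@H](CC(=O)O)C(=O)O)cc2)C(I)=C(c2ccccc2)C1=N3`, has not been measured yet. It stands to compound 3 exactly as compound 2 stands to compound 1: the change (1,2-dicarboxyethyl)amino in place of hydroxy on a carbonyl carbon is the same change, made at the same kind of place. Since compound 3 shows only a limit, > 50000 nM, and the same change left compound 2 at a limit, > 250000 nM, compound 4 is expected to give 300000 nM, most likely reported as a limit rather than a number. The step from compound 3 to compound 4 is expected to be a step that the limit leaves unreadable from compound 3 to compound 4, though with compound 3 itself at a limit this expected step rests on very little.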

Compound 4, half-maximal inhibitory concentration: > 250000 nM
Compound 4 gave a limit, no number (the forecaster's own chance of this, stated with the estimate: 90%); the middle value lies beyond the limit too.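

In this assay compound 4 gives only a limit of the assay, > 250000 nM. Compound 3 also gives only a limit, > 50000 nM, so no size can be read for the change from compound 3 to compound 4. Going by these compounds, with all four compounds at limits, it stays open what concentration of any of them would inhibit these cells by half, and whether (1,2-dicarboxyethyl)amino in place of hydroxy changes that concentration at all.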